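Hydroxy side chain: phenyl to propyl in compound 3

The compounds below may be only part of what the source reports. "The series", "measured", "known", "first", "only" and "open" are said of these compounds alone.

Compound 2 `O=C(NCc1cc(Cl)ccc1-n1cnnn1)[C@@H]1CC=NN1C(=O)[C@H](O)Cc1ccccc1` gives 1400 nM in a functional assay on a cell-free system (plasma, Homo sapiens), with a stated time of 3 min (on this read-out lower numbers stand for stronger inhibition and higher numbers for weaker inhibition), and stands at the high end of the two numbers shown; compound 1 `Cc1cccc([C@@H](O)C(=O)N2N=CC[C@H]2C(=O)NCc2cc(Cl)ccc2-n2cnnn2)c1` gives 830 nM in this assay, within the scatter of compound 2. Compound 3 `CCCC[C@@H](O)C(=O)N1N=CC[C@H]1C(=O)NCc1cc(Cl)ccc1-n1cnnn1` differs from compound 2 by propyl in place of phenyl on a saturated chain carbon, two bonds along the chain from a carbonyl carbon and an oxygen on a saturated carbon. Within the data shown here, the one step touching this position, a 1.7-fold higher number from compound 1 to compound 2 (0.23 log units; within the scatter), was small. Among the measured compounds shown here, no measured step removes the ring entirely, so the guide is weak. For compound 3 a modest rise in number is expected, a 1.8-fold higher number from compound 2 to compound 3 (0.25 log units; within the scatter), not firmly beyond the scatter. Compound 3 is expected to give 2500 nM, in the range 900 nM to 7000 nM.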

Compound 3, half-maximal inhibitory concentration: 610 nM
Compound 3: middle estimate off by 4.1-fold (0.61 log units), on the high side; measured number below the stated range.
By their numbers in this assay, from the lowest: compounds 3, 1 and 2 (each within the scatter of the next, the first and the last beyond it).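

Among these compounds, an aromatic ring on the side chain is not required for activity: propyl in place of phenyl gives a 2.3-fold lower number from compound 2 to compound 3 (0.36 log units; beyond the scatter) in this assay and is the first step at this position to pass the scatter. The open chain of compound 3 and the 3-methylphenyl group of compound 1 are not separated, with butyl in place of 3-methylphenyl giving a 1.4-fold lower number from compound 1 to compound 3 (0.13 log units; within the scatter) on this read-out. No measured evidence bears on the origin of this result. From the compounds shown here alone, how a longer chain, or a chain ending in an amine or a carboxylic acid, would read in this assay stays open.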